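The compounds below may be only part of what the source reports. "The series", "measured", "known", "first", "only" and "open" are said of these compounds alone.

Measured compounds in an ADME assay on Vero cells (Chlorocebus sabaeus) for cytotoxicity, with a stated time of 72 h; a higher number here means a weaker inhibitor, a lower number a stronger inhibitor:

Compound 1 `Cn1c(CO[C@@H]2COc3nc([N+](=O)[O-])cn3C2)cnc1-c1ccc(F)cc1` gives > 128000 nM, a limit of the assay and not a number.
Compound 2 `Cn1c(CO[C@@H]2COc3nc([N+](=O)[O-])cn3C2)cnc1-c1ccc(OC(F)(F)F)cc1` gives > 128000 nM, a limit of the assay and not a number.
Compound 3 `O=[N+]([O-])c1cn2c(n1)OC[C@@H](OCc1nnn(-c3ccc(F)cc3)n1)C2` gives > 128000 nM, a limit of the assay and not a number.

Compound 1 and compound 2 differ in one place: trifluoromethoxy in place of fluoro on an aromatic carbon. The step that the two limits leave unreadable from compound 1 to compound 2 stays unreadable due to the limit of > 128000 nM in this assay, at which 3 of the 3 values shown sit, so no size can be given for it. Compound 3 carries a different core from compound 1; the difference between the two cores is not broken down here. Within the data shown here, its single value sits at the same limit as the other two.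

Compound 4 `O=[N+]([O-])c1cn2c(n1)OC[C@@H](OCc1nnn(-c3ccc(OC(F)(F)F)cc3)n1)C2` is not yet measured in this assay. Against compound 3 it shows (trifluoromethoxy in place of fluoro on an aromatic carbon), the same change already made from compound 1 to compound 2, at the same place. For that pair the step that the limit leaves unreadable from compound 3 to compound 4 is expected to be flat, resting on compound 1 and compound 2, both held at the limit described by the limit of > 128000 nM in this assay, at which 3 of the 3 values shown sit, and on compound 3 itself standing there. Compound 4 is therefore estimated at 150000 nM, most likely again returned only as a limit.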

Compound 4, half-maximal inhibitory concentration: > 128000 nM
Compound 4 was reported as a limit; the forecaster's own chance of this, stated with the estimate: 88%; the middle value is on the limit's open side.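

Compound 4 also gives > 128000 nM in this assay, a limit of the assay and not a number. No new step can be read from compound 3 to compound 4 because the result again sits at the limit: the limit of > 128000 nM in this assay, at which 4 of the 4 values shown sit.

The compounds shown leave open whether trifluoromethoxy in place of fluoro changes the half-maximal inhibitory concentration on either core.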